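The source may report more compounds than this note shows. Statements on the series, on what has been measured and on what is new or still open speak of the compounds shown alone.

Compound 1 `O=C1O[C@H]([C@@H](O)Cn2cc(CNS(=O)(=O)c3ccc(F)cc3)nn2)C(OCc2ccccc2)=C1OCc1ccccc1`: 22900 nM
Compound 2 `COc1ccccc1-c1cn(C/C=C2\OC(=O)C(OCc3ccccc3)=C2OCc2ccccc2)nn1`: > 100000 nM

Within the data shown here, in a functional assay on HCT-116 cells (Homo sapiens) for antiproliferative activity, read by MTT assay, with a stated time of 72 h (on this read-out lower numbers stand for stronger inhibition and higher numbers for weaker inhibition), compound 1 gives 22900 nM, the only actual number so far. The entry for compound 2, > 100000 nM, is a limit of this assay.

Compound 3 `O=C1O[C@H]([C@@H](O)Cn2cc(CCCCl)nn2)C(OCc2ccccc2)=C1OCc1ccccc1` is still to be measured. It keeps the core of compound 1 and carries 2-chloroethyl in place of ((4-fluorophenyl)sulfonyl)amino on a saturated chain carbon bound to an aromatic carbon. Among the measured compounds shown here, no measured step covers this exchange, so the expectation is loose. The estimated step, a 1.3-fold higher number from compound 1 to compound 3 (0.12 log units; within the scatter), is expected to stay within the usual scatter. For compound 3 the expected value is 30000 nM, with an estimated range of 8000 nM to 100000 nM.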

Compound 3, half-maximal inhibitory concentration: 36100 nM
For compound 3 the middle estimate is 1.2-fold (0.08 log units) below the measured one, within the range that was stated.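

In this assay, replacing ((4-fluorophenyl)sulfonyl)amino with 2-chloroethyl on a saturated chain carbon bound to an aromatic carbon gives a 1.6-fold higher number from compound 1 to compound 3 (0.20 log units; within the scatter) and so leaves the read-out within the scatter. For these two compounds, the aromatic ring and the hydrogen-bond donor and acceptors of the departing group are therefore not required to keep this level of activity. Nothing shown bears on why the two values stay level.

Going by these compounds, whether an amine, a carboxylic acid or a longer chain at this place would move the number beyond the scatter remains open.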